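A few compounds are considered here, and "the series" means these few. Any claim that something is new, unique, unknown or untested is made for them only; others in the source may bear on it.

In a functional assay on HEK293 cells (Homo sapiens) for cytotoxicity (on this read-out lower numbers stand for higher toxicity in this test and higher numbers for lower toxicity in this test), compound 1 `COc1ccc([C@H]2CC(=O)N(c3cccc(NCCCc4ccccc4)c3)C2)cc1OC1CCCC1` gives > 10000 nM, which is a limit of the assay and not a number. Compound 2 `COc1ccc([C@H]2CC(=O)N(c3cccc(NC(=O)C(C)=O)c3)C2)cc1OC1CCCC1` gives > 10000 nM, which is likewise a limit. Among the compounds with values here, compound 3 `COc1ccc(OC)c(S(=O)(=O)Nc2cccc(N3C[C@@H](c4ccc(OC)c(OC5CCCC5)c4)CC3=O)c2)c1` gives 7590 nM, the only actual number so far. The other two compounds stand at the limit of > 10000 nM in this assay, at which 2 of the 3 values shown sit.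

Compound 4 `COc1ccc([C@H]2CC(=O)N(c3cccc(NS(=O)(=O)c4c(F)cccc4F)c3)C2)cc1OC1CCCC1` carries 2,6-difluorophenyl in place of 2,5-dimethoxyphenyl on a sulfonyl sulfur. Within the data shown here, the only measured step is a step that the two limits leave unreadable from compound 1 to compound 2. It concerns a different substituent, on a nitrogen on an aromatic ring, and it gives no size to carry over. Among the measured compounds shown here, no measured step therefore bears directly on this change, and no shift beyond the scatter, in either direction, is expected in this assay. The best anchor remains compound 3 at 7590 nM. The expected step is a 1.1-fold higher number from compound 3 to compound 4 (0.02 log units; within the scatter). The estimated value for compound 4 is 8000 nM, with an expected range from 4000 nM to 16000 nM.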

Compound 4, half-maximal cytotoxic concentration: > 10000 nM
Compound 4: only a limit was reported; the forecaster's own chance of this, stated with the estimate: 45%; middle value at least 1.2-fold (0.09 log units) from the limit.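

In this assay compound 4 gives > 10000 nM, which is a limit of the assay and not a number. Within the data shown here, replacing 2,5-dimethoxyphenyl with 2,6-difluorophenyl on the sulfonyl sulfur gives the first readable step at this position, an at least 1.3-fold higher number from compound 3 to compound 4 (0.11 log units; that floor lies within the scatter), so the change has a floor but no measured size, and that floor does not establish a shift beyond the scatter. Compound 3 remains the only compound with an actual number, while the others share one limit: the limit of > 10000 nM in this assay, at which 3 of the 4 values shown sit.

As far as these compounds go, the steps to compound 4 from compound 1 and compound 2 cannot be read, and the true size of the step from compound 3 stays open. Also open, from the compounds shown here alone, is how this assay would read with a methyl group or an aminophenyl group on the sulfonyl sulfur.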